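Benzofuranyl for thienyl amide on two chain cores

The source may report more compounds than this note shows. Statements on the series, on what has been measured and on what is new or still open speak of the compounds shown alone.

Compound 1 `CCCCCCCCCCCCNC(=O)[C@@H](NC(=O)c1cccs1)[C@@H](C)O` and compound 2 `CCCCCCCCCCCCNC(=O)[C@@H](NC(=O)c1cc2ccccc2o1)[C@@H](C)O` share one core; compound 3 `CCCCCCCCCCCCCCCCCCNC(=O)[C@@H](NC(=O)c1cccs1)[C@@H](C)O` and compound 4 `CCCCCCCCCCCCCCCCCCNC(=O)[C@@H](NC(=O)c1cc2ccccc2o1)[C@@H](C)O` share another. The two cores differ in the chain only: hexyl in place of hydrogen on a saturated chain carbon, ten or more bonds along the chain from an amide-type nitrogen. In a functional assay on HepG2 cells (Homo sapiens) for cytotoxicity, read by MTT assay, with a stated time of 48 h (on this read-out lower numbers stand for stronger inhibition and higher numbers for weaker inhibition), compound 1 gives 30100 nM. In this assay compound 3 gives 92000 nM, and the chain extension is read as a 3.1-fold higher number from compound 1 to compound 3 (0.49 log units; beyond the scatter). Compound 3 has the highest number of the three measured compounds, and its steps to compound 1 and compound 2 are both beyond the scatter.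

The aryl change on the first core is 1-benzofuran-2-yl in place of thiophen-2-yl on a carbonyl carbon. In this assay compound 2 gives 22900 nM, so the step is a 1.3-fold lower number from compound 1 to compound 2 (0.12 log units; within the scatter), which stays within the scatter. Compound 4 carries the same change on the second core: 1-benzofuran-2-yl in place of thiophen-2-yl on a carbonyl carbon. The surroundings of the change are described in the same words for both pairs, so it is treated as the same change, made twice in all among the compounds here.

For the measured compounds named here, the step from compound 3 to compound 4 is expected to be a 1.3-fold lower number from compound 3 to compound 4 (0.11 log units; within the scatter), resting on the single earlier instance, a 1.3-fold lower number from compound 1 to compound 2 (0.12 log units; within the scatter), which gave no movement beyond the scatter. Going by the values given here, with only one prior example, the expectation is loose. Compound 4 is therefore estimated at 72000 nM in this assay, most likely between 36000 nM and 145000 nM. Since compound 3 already sits at the high end of the measured numbers, a reported limit rather than a number cannot be excluded for compound 4.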

Compound 4, half-maximal inhibitory concentration: > 200000 nM
Compound 4: a limit, no number; the forecaster's own chance of this, stated with the estimate: 20%; at least 2.7-fold (0.44 log units) between middle value and limit.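

Carrying the change from thiophen-2-yl to 1-benzofuran-2-yl across the two cores does not work in this assay: a step within the scatter on the core of compound 1 gives no guide to an at least 2.1-fold higher number from compound 3 to compound 4 (0.33 log units; beyond the scatter), and the two steps differ: the same change on two cores in this assay, a 1.3-fold lower number (0.12 log units; within the scatter) from compound 1 to compound 2 and an at least 2.1-fold higher number (0.33 log units; beyond the scatter) from compound 3 to compound 4, at least 2.8-fold (0.45 log units) apart, beyond the scatter of two such steps

Seen from the chain, hexyl in place of hydrogen gives an at least 8.7-fold higher number from compound 2 to compound 4 (0.94 log units; beyond the scatter), so the chain step on the 1-benzofuran-2-yl amide does not match the one on the thiophen-2-yl amide: the same change on two cores in this assay, a 3.1-fold higher number (0.49 log units; beyond the scatter) from compound 1 to compound 3 and an at least 8.7-fold higher number (0.94 log units; beyond the scatter) from compound 2 to compound 4, at least 2.8-fold (0.45 log units) apart, beyond the scatter of two such steps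

Compound 4 gives > 200000 nM, which is a limit and not a number, so the two new steps have no upper size, and these two pairs show a dependence on the core without showing its cause: the limit of > 200000 nM in this assay, at which 1 of the 4 values shown sits.

Still open, as far as these compounds go, is whether a furan-2-yl or phenyl amide would follow the thiophen-2-yl or the 1-benzofuran-2-yl amide on either core. Also open, from the compounds shown here alone, is where the dependence on the core sets in along the chain, for instance with a tetradecyl or hexadecyl chain on the amide nitrogen, and whether a free amine or a carboxylic acid at the chain end would change the picture.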